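The source may report more compounds than this note shows. Statements on the series, on what has been measured and on what is new or still open speak of the compounds shown alone.

Compound 1 `CCCC(CCC)Nc1nc(C)nc2c1nnn2-c1ccc(Br)cc1Br` gives 0.8 nM.
Compound 2 `Cc1nc(N2CCCC2)c2nnn(-c3ccc(C(C)C)cc3Br)c2n1` gives 194 nM.
Compound 3 `CCCCN(CC)c1nc(C)nc2c1nnn2-c1ccc(C(C)=O)cc1Br` gives 33.7 nM.

All three were measured in an in vitro assay on 293-EBNA cells for binding affinity to corticotropin-releasing factor receptor 1 (Homo sapiens); on this read-out lower numbers stand for stronger inhibition and higher numbers for weaker inhibition. Among the three numbers shown, compound 2 has the highest; compound 3 sits at a lower number and compound 1 at the lowest, and both of these gaps lie beyond the usual scatter of this assay. The unmeasured compound 4 `CCC(CO)Nc1nc(C)nc2c1nnn2-c1ccc(C(C)C)cc1Br` differs from compound 2 in a single place: (1-(hydroxymethyl)propyl)amino in place of pyrrolidin-1-yl on an aromatic carbon. Among the compounds with values here, no measured pair of compounds shows this exact change, so its effect cannot be read directly from the data. Because compound 1 gives 0.8 nM on the shared core, a move toward a lower number looks more likely than a move toward a higher one, though the size remains uncertain. The step from compound 2 to compound 4 is expected to be a 16-fold lower number from compound 2 to compound 4 (1.21 log units; beyond the scatter) in this assay, a shift beyond the scatter. Compound 4 is therefore estimated at 12 nM, with a likely range from 2 nM to 70 nM.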

Compound 4, inhibition constant: 25.3 nM
For compound 4 the middle estimate is 2.1-fold (0.32 log units) below the measured one; low and high end bracket the measured number.
By their numbers in this assay, from the lowest: compound 1; then compounds 4 and 3 (each within the scatter of the next); then compound 2.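

In this assay, putting (1-(hydroxymethyl)propyl)amino in place of pyrrolidin-1-yl on this aromatic carbon gives a 7.7-fold lower number from compound 2 to compound 4 (0.88 log units; beyond the scatter), the first direct sign that the number responds to a change at this position. The swap alters several things at once: the ring is gone, an oxygen is added, and the entering group has hydrogen-bond donors, which pyrrolidin-1-yl lacks, so this single step cannot show which of these counts. Nothing measured here explains why the number falls.

The compounds shown leave open what the hydroxyl contributes, which a comparison with the same branched chain ending in a plain methyl group instead of hydroxymethyl could test. They also leave open how a methoxymethyl branch or a longer chain would behave at this position.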